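The compounds below may be only part of what the source reports. "The series", "measured", "known", "first", "only" and "open" are said of these compounds alone.

In an ADME assay on THP-1 cells (Homo sapiens) for cytotoxicity, read by flow cytometry and propidium iodide staining, with a stated time of 72 h (a lower number here means a stronger inhibitor, a higher number a weaker inhibitor), compound 2 `Cc1nc(CS(=O)(=O)c2ccccc2)c([N+](=O)[O-])n1C` gives > 846000 nM, which is a limit and not a number. Compound 1 `Cn1cnc(CS(=O)(=O)c2ccccc2)c1[N+](=O)[O-]` gives > 888000 nM, also a limit. Compound 3 `Cc1nc(CS(=O)(=O)c2ccc(Br)cc2)c([N+](=O)[O-])n1C` gives 326000 nM, a true number. Compound 4 `Cc1nc(CS(=O)(=O)c2ccccc2)c([N+](=O)[O-])n1CCO` differs from compound 2 by hydroxymethyl in place of hydrogen on a saturated chain carbon bound to an aromatic nitrogen, which turns methyl into 2-hydroxyethyl. Neither measured step touches that chain. One is a step that the two limits leave unreadable from compound 1 to compound 2, and the other, on an aromatic carbon, is an at least 2.5-fold lower number from compound 2 to compound 3 (0.41 log units; beyond the scatter). With so little bearing on the change, no shift beyond the scatter is expected in this assay, and a limit is again the likely report. The expected result is an at least 1.1-fold lower number from compound 2 to compound 4 (0.04 log units; that floor lies within the scatter). For compound 4 the estimated value is 760000 nM, with an expected range of 350000 nM to 1000000 nM.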

Compound 4, half-maximal inhibitory concentration: > 768000 nM
Compound 4 gave a limit, no number; the forecaster's own chance of this, stated with the estimate: 75%; at least 1.0-fold (0.00 log units) between middle value and limit.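

In this assay compound 4 gives > 768000 nM, a limit and not a number. Compound 2 gives > 846000 nM, also a limit, so the step between compound 2 and compound 4 cannot be read. The compounds shown leave open whether 2-hydroxyethyl in place of methyl changes the result at all.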